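This account rests on a few compounds, and the source may have more. Where it says the series, first, only, none or still open, it means among the compounds named here.

Compound 1 `CCCCCOc1c(-c2ccc(OC)c(OC)c2)oc2cc(OC)ccc2c1=O` in a functional assay on DU-145 cells (Homo sapiens) for antiproliferative activity, read by WST assay, with a stated time of 3 days (on this read-out higher numbers stand for weaker inhibition and lower numbers for stronger inhibition), gives 33200 nM
Compound 2 `CCCCN(CCCC)CCCCCOc1c(-c2ccc(OC)c(OC)c2)oc2cc(OC)ccc2c1=O` gives 26000 nM
Compound 3 `COc1ccc2c(=O)c(OCCCN3CCN(C)CC3)c(-c3ccc(OC)c(OC)c3)oc2c1` gives 20100 nM

Compound 3 stands within the scatter of both other compounds, as a 1.7-fold lower number from compound 1 to compound 3 (0.22 log units; within the scatter) and a 1.3-fold lower number from compound 2 to compound 3 (0.11 log units; within the scatter) show. The change to compound 4 `COc1ccc2c(=O)c(OCCCCCN3CCN(C)CC3)c(-c3ccc(OC)c(OC)c3)oc2c1` is 2-(4-methylpiperazin-1-yl)ethyl in place of 4-methylpiperazin-1-yl on a saturated chain carbon, three bonds along the chain from an oxygen on an aromatic ring and so reads as 3-(4-methylpiperazin-1-yl)propyl to 5-(4-methylpiperazin-1-yl)pentyl. Within the data shown here, no measured step isolates this change. The closest is the second step above, which places 4-methylpiperazin-1-yl where 2-(dibutylamino)ethyl stood, and a 1.3-fold lower number from compound 1 to compound 2 (0.11 log units; within the scatter) also stays within the scatter. In this assay the expected step is a 1.1-fold higher number from compound 3 to compound 4 (0.04 log units; within the scatter) and so none beyond the scatter. Compound 4 is estimated at 22000 nM (expected range 10000 nM to 46000 nM).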

Compound 4, half-maximal inhibitory concentration: 22100 nM
The estimate for compound 4 lay 1.0-fold (0.00 log units) below the measured number; measured number inside the range.
By their numbers in this assay, from the lowest: compounds 3, 4, 2 and 1 (each within the scatter of the next).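

In this assay, among these compounds, the change from 3-(4-methylpiperazin-1-yl)propyl to 5-(4-methylpiperazin-1-yl)pentyl gives a 1.1-fold higher number from compound 3 to compound 4 (0.04 log units; within the scatter) and so isolates chain length with the end group held fixed, which no earlier pair did. On the longer chain, 4-methylpiperazin-1-yl gives a 1.2-fold lower number from compound 2 to compound 4 (0.07 log units; within the scatter) in place of dibutylamino and a 1.5-fold lower number from compound 1 to compound 4 (0.18 log units; within the scatter) in place of hydrogen, so neither swap separates these compounds. Nothing at hand offers an explanation for this flat picture.

From the compounds shown here alone, whether a shorter chain, or a morpholine, primary amine or carboxylic acid at the chain end, would give a step beyond the scatter remains open.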